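Trifluoromethyl for methyl on the pyrimidine of compound 2

A few compounds are considered here, and "the series" means these few. Any claim that something is new, unique, unknown or untested is made for them only; others in the source may bear on it.

Among the compounds with values here, compound 2 `Cc1nccc(N2CCCC3CC(C4(C(=O)Nc5ccc(F)cc5)CCC4)CCC32)n1` stands at the low end of the two numbers known so far: in an assay on blood for inhibition of Indoleamine 2,3-dioxygenase 1 (Homo sapiens) (on this read-out higher numbers stand for weaker inhibition and lower numbers for stronger inhibition), compound 2 gives 0.29 nM. Within the data shown here, its only measured neighbour is compound 1 `O=C(C1CC1)N1CCCC2CC(C3(C(=O)Nc4ccc(F)cc4)CCC3)CCC21`, which in this assay gives 0.86 nM; the step of a 3.0-fold lower number from compound 1 to compound 2 (0.47 log units; beyond the scatter) comes from exchanging the cyclopropylcarbonyl on the ring amine nitrogen for 2-methylpyrimidin-4-yl.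

Compound 3 `O=C(Nc1ccc(F)cc1)C1(C2CCC3C(CCCN3c3ccnc(C(F)(F)F)n3)C2)CCC1` keeps the pyrimidine and changes only the small group on it: trifluoromethyl in place of methyl on an aromatic carbon, on an aromatic carbon of a six-membered aromatic ring with 2 nitrogen, between two ring nitrogen atoms.

Among the measured compounds shown here, no measured step touches this group. For the measured compounds named here, the one step known, from compound 1 to compound 2, concerns the whole ring substituent on the amine and says nothing about methyl against trifluoromethyl. Going by the values given here, with no bearing step, the author expects the number of compound 3 in this assay to stay close to that of compound 2, a step of a 1.2-fold higher number from compound 2 to compound 3 (0.08 log units; within the scatter) that is not expected to exceed the scatter. The estimate for compound 3 is therefore 0.35 nM, within 0.1 nM to 1.2 nM.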

Compound 3, half-maximal inhibitory concentration: 0.1 nM
For compound 3 the middle estimate is 3.5-fold (0.54 log units) above the measured one; the range from low to high includes it.
By their numbers in this assay, from the lowest: compound 3; then compound 2; then compound 1.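

The carbon between two ring nitrogen atoms of the pyrimidine turns out to respond to a change of one small group in this assay: trifluoromethyl in place of methyl gives a 2.9-fold lower number from compound 2 to compound 3 (0.46 log units; beyond the scatter), a modest step but one that lies beyond the scatter. Until now, only the exchange of the entire substituent on the ring amine nitrogen had been seen to move the number, and this smaller change adds to that exchange, so that the full replacement of cyclopropylcarbonyl by 2-(trifluoromethyl)pyrimidin-4-yl amounts to an 8.6-fold lower number from compound 1 to compound 3 (0.93 log units; beyond the scatter). Nothing available explains why the trifluoromethyl compound gives the lower number.

With a single pair at this carbon, the compounds shown do not establish a trend, and it remains open where a hydrogen, a chlorine, a methoxy group or a nitrile on the same carbon would fall in this assay. Going by these compounds, it is also open whether trifluoromethyl would give a step of similar direction on another carbon of the pyrimidine, or on a ring with a different number of nitrogen atoms.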